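Fluoro for chloro on the triazole aryl of compound 2

The compounds below may be only part of what the source reports. "The series", "measured", "known", "first", "only" and "open" are said of these compounds alone.

Measured compounds:
- compound 1 `Cc1c(O)ccc2c1[C@H](Cn1cc(-c3ccc(Cl)cc3)nn1)[C@@]13CC(=O)[C@@](C)(CC[C@@H]21)C3`: in a functional assay on SW480 cells (Homo sapiens) for cytotoxicity, read by MTT assay, with a stated time of 4 days (a higher number here means a weaker inhibitor, a lower number a stronger inhibitor), compound 1 gives > 20000 nM, a limit of the assay.
- compound 2 `Cc1ccc(S(=O)(=O)Oc2ccc3c(c2C)[C@H](Cn2cc(-c4ccc(Cl)cc4)nn2)[C@@]24CC(=O)[C@@](C)(CC[C@@H]32)C4)cc1`: in this assay compound 2 gives > 20000 nM, a limit of the assay.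
- compound 3 `C=C1C[C@]23C[C@@]1(O)CC[C@H]2c1ccc(O)c(C)c1[C@@H]3Cn1cc(-c2ccc(OC)cc2)nn1`: in this assay compound 3 gives > 20000 nM, a limit of the assay.

Compound 2 stands where every other value in the series stands: at a limit of the assay, with no number behind it. Among the measured compounds shown here, the only single-point step measured so far, a step that the two limits leave unreadable from compound 1 to compound 2, joins two limits and therefore carries no readable size. The whole picture is summed up by the limit of > 20000 nM in this assay, at which 3 of the 3 values shown sit; nothing in the series has yet produced a number below the limit.

Compound 4 `Cc1ccc(S(=O)(=O)Oc2ccc3c(c2C)[C@H](Cn2cc(-c4ccc(F)cc4)nn2)[C@@]24CC(=O)[C@@](C)(CC[C@@H]32)C4)cc1` differs from compound 2 by fluoro in place of chloro on an aromatic carbon. For the measured compounds named here, no measured step touches this pair of halogens, so there is no evidence for any direction. Given that compound 2 sits at the limit > 20000 nM, the expectation for compound 4 in this assay is that it too returns a limit, and its estimated value is 30000 nM, with a range from 15000 nM to 80000 nM. The step that this estimate implies is a step that the limit leaves unreadable from compound 2 to compound 4, which is expected to be nothing beyond the scatter.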

Compound 4, half-maximal inhibitory concentration: > 20000 nM
Compound 4 was reported as a limit; the forecaster's own chance of this, stated with the estimate: 85%; the middle value does not contradict the limit.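

Compound 2 and compound 4 are both reported only as limits in this assay, so the step from chloro to fluoro between them cannot be read, and the series remains flat: the limit of > 20000 nM in this assay, at which 4 of the 4 values shown sit.

The compounds shown leave open how fluoro and chloro compare in this assay, and which change to the shared core or its substituents would give a measurable value there.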